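Swapping the sulfonyl aryl group: from compound 1 to compound 3

A few compounds are considered here, and "the series" means these few. Any claim that something is new, unique, unknown or untested is made for them only; others in the source may bear on it.

Measured compounds:
compound 1, `CC(=O)Nc1ccc(S(=O)(=O)NNC(=O)c2cccnc2Nc2ccc(Cl)cc2)cc1`: < 100000 nM
compound 2, `O=C(NNS(=O)(=O)c1ccc(F)cc1)c1cccnc1Nc1ccc(Cl)cc1Cl`: 15500 nM

Both measured compounds were examined in a functional assay on HOP-92 cells (Homo sapiens) for antiproliferative activity; a higher number here means a weaker inhibitor of growth, a lower number a stronger inhibitor of growth. For compound 1 the result is only a limit, < 100000 nM, not a number. This is where compound 1 stands: the limit of < 100000 nM in this assay, at which 1 of the 2 values shown sits. Going by the values given here, compound 2 differs from compound 1 in several places, and no single step connects the two. In this assay compound 2 gives 15500 nM, and the two values are simply shown side by side.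

Compound 3, `O=C(NNS(=O)(=O)c1ccc(Cl)cc1Cl)c1cccnc1Nc1ccc(Cl)cc1`, has not yet been measured. It differs from compound 1 in one place: 2,4-dichlorophenyl in place of 4-acetamidophenyl on a sulfonyl sulfur. Among the compounds with values here, since compound 1 is known only as a limit, no measured step gives a scale for this change, and the expectation must rest on the limit of compound 1 and the value of compound 2. Compound 3 is therefore expected to sit somewhere near the range of compound 2, with the step from compound 1 estimated as a step that the limit leaves unreadable from compound 1 to compound 3. The estimate for compound 3 in this assay is 25000 nM, within a range from 5000 nM to 90000 nM, with a real chance that only a limit is reported.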

Compound 3, concentration for 50% growth inhibition: 14800 nM
Compound 3: middle estimate off by 1.7-fold (0.23 log units), on the high side; measured number inside the range.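

In this assay compound 1 is known only as a limit, so no step from compound 1 to compound 3 can be read: the limit of < 100000 nM in this assay, at which 1 of the 3 values shown sits.

The compounds shown leave open whether 2,4-dichlorophenyl in place of 4-acetamidophenyl on a sulfonyl sulfur strengthens growth inhibition, weakens it or leaves it unchanged in this assay.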